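The source may report more compounds than this note shows. Statements on the series, on what has been measured and on what is new or still open speak of the compounds shown alone.

Compound 2 `CNC(=O)c1cc(C(=O)NC)c2c(c1)[C@H](c1ccccc1)CO2` and compound 1 `CNC(=O)c1cc(C(=O)N[C@H]2[C@@H]3COC[C@@H]32)cc2c1OC[C@H]2c1ccccc1` share one core and have both been measured in a physicochemical assay for solubility; on this read-out higher numbers stand for higher solubility and lower numbers for lower solubility. In this assay compound 2 gives >= 130 ug/mL, which is a limit of the measurement rather than a number. In this assay compound 1 gives >= 165 ug/mL, likewise a limit. Going by the values given here, the single step between the two, a step that the two limits leave unreadable from compound 1 to compound 2, therefore has no readable size, since the two limits the limit of >= 130 ug/mL in this assay, at which 1 of the 2 values shown sits, and the limit of >= 165 ug/mL in this assay, at which 1 of the 2 values shown sits, leave it open. Compound 3 `CNC(=O)c1cc(C(N)=O)cc2c1OC[C@H]2c1ccccc1` differs from compound 2 by hydrogen in place of methyl on an amide-type nitrogen. Among the compounds with values here, no measured step bears directly on this change; the only known step, from compound 1 to compound 2, is unreadable and concerns a different group, also on an amide-type nitrogen. Both measured compounds sit at limits of this assay, so compound 3 is expected to remain in that same region, and the step that the limit leaves unreadable from compound 2 to compound 3 is estimated as no change beyond the scatter. Compound 3 is accordingly estimated at 150 ug/mL in this assay, within a range from 60 ug/mL to 400 ug/mL.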

Compound 3, solubility: >= 144 ug/mL
Compound 3 gave a limit, no number (the forecaster's own chance of this, stated with the estimate: 60%); the middle value does not contradict the limit.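

In this assay compound 3 gives >= 144 ug/mL, which is a limit and not a number. Going by these compounds alone, with compound 1 and compound 2 also at limits, no step among the three compounds can be read. The compounds shown leave open the actual solubility of each, and so whether hydrogen in place of methyl on an amide-type nitrogen changes it at all.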